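This account rests on a few compounds, and the source may have more. Where it says the series, first, only, none or still open, it means among the compounds named here.

Measured in a functional assay on HCT-15 cells (Homo sapiens); a lower number here means that less compound is needed, a higher number that more compound is needed for the effect:
- compound 1 `CCOC(=O)C(=O)N1N=C(c2ccc(N(C)C)cc2)OC1c1cc(OC)c(OC)c(OC)c1`: 45 uM
- compound 2 `COc1cc(C2OC(c3ccc(N(C)C)cc3)=NN2C(=O)CN=[N+]=[N-])cc(OC)c1OC`: 0.15 uM

Of these two, compound 2 has the lower number, at 0.15 uM. Compound 3 `COc1cc(C2OC(c3ccc(N(C)C)cc3)=NN2C(=O)CNC(C)=O)cc(OC)c1OC` differs from it as follows: acetamido in place of azido on a saturated chain carbon bound to a carbonyl carbon. Among the measured compounds shown here, only one measured step bears on this, the large 300-fold lower number from compound 1 to compound 2 (2.48 log units; beyond the scatter), with azidomethyl in place of ethoxycarbonyl on a carbonyl carbon. It shows that this assay can respond strongly to a change in this part of the structure, but it says nothing about acetamido. The expected change is a 13-fold higher number from compound 2 to compound 3 (1.12 log units; beyond the scatter), towards a higher number, beyond the scatter and smaller than the measured step. For compound 3 the estimate is 2 uM, with an expected range of 0.3 uM to 20 uM.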

Compound 3, concentration for half-maximal effect: 0.18 uM
Compound 3: middle estimate off by 11-fold (1.05 log units), on the high side; measured number below the stated range.
By their numbers in this assay, from the lowest: compounds 2 and 3 (each within the scatter of the next); then compound 1.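

In this assay, acetamido in place of azido on a saturated chain carbon bound to a carbonyl carbon gives a 1.2-fold higher number from compound 2 to compound 3 (0.08 log units; within the scatter) and so leaves the number unchanged within the scatter. The large step from ethoxycarbonyl is thus not specific to azidomethyl, as acetamidomethyl also gives a 250-fold lower number from compound 1 to compound 3 (2.40 log units; beyond the scatter). No supporting data explain this result. From the compounds shown here alone, whether an amine or a carboxylic acid on the same carbon would keep the number this low remains open, as does the effect of a longer chain between the carbonyl and acetamido.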